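A few compounds are considered here, and "the series" means these few. Any claim that something is new, unique, unknown or untested is made for them only; others in the source may bear on it.

In a functional assay on DU-145 cells (Homo sapiens) for inhibition, read by trypan blue exclusion, with a stated time of 96 h (a lower number here means a stronger inhibitor of growth, a higher number a weaker inhibitor of growth), compound 1 `COc1cc(/C=C(/Sc2ccc(Br)cc2)C(=O)c2ccc(Br)cc2)ccc1F` gives 10000 nM. Compound 3 `O=C(/C(=C\c1ccc(F)cc1Cl)Sc1ccc(Br)cc1)c1ccc(Br)cc1` gives 1000 nM, and the change between them shows a 10-fold lower number from compound 1 to compound 3 (1.00 log units; beyond the scatter). Compound 2 `Nc1c(Br)cc(Br)cc1/C=C(/Sc1ccc(Br)cc1)C(=O)c1ccc(Br)cc1` gives only a limit of the assay, > 100000 nM. On the numbers shown compound 2 stands at the weak end, since an at least 10-fold higher number from compound 1 to compound 2 (1.00 log units; beyond the scatter) and an at least 100-fold lower number from compound 2 to compound 3 (2.00 log units; beyond the scatter). Compound 4 `Nc1c(Br)cc(Br)cc1/C=C(\C(=O)c1ccc(Br)cc1)S(=O)(=O)c1ccc(Br)cc1` differs from compound 2 by (4-bromophenyl)sulfonyl in place of (4-bromophenyl)sulfanyl on a double-bonded chain carbon bound to a carbonyl carbon and a double-bonded chain carbon. Within the data shown here, none of the measured steps touches this part of the molecule; each of them changes the aryl group on the other chain carbon, so no measured step bears directly on this change. Compound 2 sits at the limit of > 100000 nM in this assay, at which 1 of the 3 values shown sits. Compound 4 is therefore expected to stay near that limit, with a number no higher from compound 2 to compound 4 (the limit leaves the size open). Compound 4 is estimated at 100000 nM, between 30000 nM and 300000 nM.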

Compound 4, concentration for 50% growth inhibition: 25000 nM
Compound 4: the middle estimate sits 4.0-fold (0.60 log units) above what was measured, and the stated range ends above it.
By their numbers in this assay, from the lowest: compound 3; then compound 1; then compound 4. At a limit, above all of these: compound 2.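

In this assay, this is the first change shown at the sulfur-bearing chain carbon rather than on the aryl group of the other chain carbon, and (4-bromophenyl)sulfonyl in place of (4-bromophenyl)sulfanyl gives an at least 4.0-fold lower number from compound 2 to compound 4 (0.60 log units; beyond the scatter). This position therefore matters for growth inhibition, even with the 2-amino-3,5-dibromophenyl group kept in place. The step gives only a minimum size, since compound 2 carries an assay limit rather than a number: the limit of > 100000 nM in this assay, at which 1 of the 4 values shown sits.

From the compounds shown here alone, whether the same change would also strengthen compound 3 remains open. So does how a (4-bromophenyl)sulfinyl or (4-bromophenyl)amino group would behave at this position.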